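Swapping pyridin-2-yl for 4-fluorophenyl on the shared core

The source may report more compounds than this note shows. Statements on the series, on what has been measured and on what is new or still open speak of the compounds shown alone.

Within the data shown here, compound 3 `OC[C@H]1O[C@@H](n2cc(-c3ccccn3)nn2)[C@H](O)[C@@H]1O` is the only member of this set with a number in a functional assay on L1210 cells (Mus musculus); on this read-out lower numbers stand for stronger inhibition and higher numbers for weaker inhibition: compound 3 gives 236000 nM. For compound 1 `CCCCCCc1cn([C@@H]2O[C@H](CO)[C@@H](O)[C@H]2O)nn1` the read-out is a limit of the assay, > 200000 nM. For compound 2 `OCc1cn([C@@H]2O[C@H](CO)[C@@H](O)[C@H]2O)nn1` the read-out is likewise a limit, > 200000 nM. Compound 4 `OC[C@H]1O[C@@H](n2cc(-c3ccc(F)cc3)nn2)[C@H](O)[C@@H]1O` differs from compound 3 by 4-fluorophenyl in place of pyridin-2-yl on an aromatic carbon. The measured steps that bear on this change, a step that the limit leaves unreadable from compound 1 to compound 3 and a step that the limit leaves unreadable from compound 2 to compound 3, carry no readable size because both start at the limit of > 200000 nM in this assay, at which 2 of the 3 values shown sit. No step beyond the scatter in this assay can therefore be expected in either direction. Compound 4 is estimated at 250000 nM, with a range from 80000 nM to 800000 nM. This expectation amounts to a step of a 1.1-fold higher number from compound 3 to compound 4 (0.03 log units; within the scatter).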

Compound 4, half-maximal inhibitory concentration: 209000 nM
The estimate for compound 4 lay 1.2-fold (0.08 log units) above the measured number; the range from low to high includes it.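

In this assay, among these compounds, the change gives a 1.1-fold lower number from compound 3 to compound 4 (0.05 log units; within the scatter), the first readable step at this aromatic carbon. It shows that 4-fluorophenyl and pyridin-2-yl are not told apart here, although the entering ring has carbon only and the hydrogen-bond acceptor leaves with the pyridin-2-yl. The steps to compound 4 from compound 1 and compound 2 cannot be read because each starts at a limit: the limit of > 200000 nM in this assay, at which 2 of the 4 values shown sit.

On these data alone, it remains open whether an amine or a carboxylic acid at this aromatic carbon would move the number in this assay beyond the scatter.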